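A few compounds are considered here, and "the series" means these few. Any claim that something is new, unique, unknown or untested is made for them only; others in the source may bear on it.

Compound 1 `CCCC[C@H](NC(=O)[C@H](CCCCN)NC(=O)[C@H](CCCNC(=N)N)NC(=O)c1ccccc1)C(N)=O` carries a plain benzoyl group on its peptide core, and in an ADME assay for permeability, using PAMPA (on this read-out lower numbers stand for lower permeability and higher numbers for higher permeability), compound 1 is reported as "impermeable" (no number reported), with no number given. Compound 2 `CCCC[C@H](NC(=O)[C@H](CCCCN)NC(=O)[C@H](CCCNC(=N)N)NC(=O)c1ccc(/C=C2\SC(=S)N(Cc3ccc(OC)cc3)C2=O)cc1)C(N)=O` bears a larger substituted group on the same core, and in this assay compound 2 gives 0.6 10^-6 cm/s. Among the measured compounds shown here, compound 2 therefore stands as the only compound here with a number, the other entry having none.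

Compound 3 `CCCC[C@H](NC(=O)[C@H](CCCCN)NC(=O)[C@H](CCCNC(=N)N)NC(=O)c1ccc(/C=C2\SC(=S)N(c3ccc(OC)cc3)C2=O)cc1)C(N)=O` differs from compound 2 in one place: 4-methoxyphenyl in place of 4-methoxybenzyl on an amide-type nitrogen in a ring. For the measured compounds named here, no measured pair with such a change is available, so the size of the step can only be expected, not read from the data. Since the two groups are of nearly the same make-up, the step of a 1.2-fold lower number from compound 2 to compound 3 (0.08 log units; within the scatter) is expected to stay within the usual scatter, in no particular direction. Compound 3 is expected to give 0.5 10^-6 cm/s, with a range from 0.25 10^-6 cm/s to 1 10^-6 cm/s.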

Compound 3, apparent permeability: 0.59 10^-6 cm/s
Compound 3: middle estimate off by 1.2-fold (0.07 log units), on the low side; the range from low to high includes it.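

In this assay, among the compounds shown here, putting 4-methoxyphenyl in place of 4-methoxybenzyl on the amide-type nitrogen in the ring gives a 1.0-fold lower number from compound 2 to compound 3 (0.01 log units; within the scatter) and so provides the first measured step at this position. The two groups share a six-membered aromatic ring of carbon only, and on this read-out this change cannot be told apart from repeat scatter. Nothing in the data shown accounts for this result.

The compounds shown leave open whether this insensitivity extends to groups of another kind on the same nitrogen, such as a plain phenyl, a longer alkyl chain, an amine or a carboxylic acid. They also leave open whether the methoxy group on the aromatic ring has any bearing on the read-out, as both compounds carry it.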